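This account rests on a few compounds, and the source may have more. Where it says the series, first, only, none or still open, it means among the compounds named here.

Measured in a functional assay on MCF7 cells (Homo sapiens) for cytotoxicity, read by MTT assay, with a stated time of 48 h; on this read-out lower numbers stand for stronger inhibition and higher numbers for weaker inhibition:
Compound 1 `C=C1CCC[C@]2(C)CCC(c3cn(-c4ccc(C(C)=O)cc4)nn3)=CC[C@@]12C`: 65400 nM
Compound 2 `C=C1CCC[C@]2(C)CCC(c3cn(-c4cccc([N+](=O)[O-])c4)nn3)=CC[C@@]12C`: 40300 nM
Compound 3 `C=C1CCC[C@]2(C)CCC(c3cn(-c4cccc(OC)c4)nn3)=CC[C@@]12C`: 56200 nM

These compounds share a core and differ only in the group on an aromatic nitrogen. Compound 3 cannot be separated from the other two: a 1.2-fold lower number from compound 1 to compound 3 (0.07 log units; within the scatter), and a 1.4-fold higher number from compound 2 to compound 3 (0.14 log units; within the scatter). Compound 4 `C=C1CCC[C@]2(C)CCC(c3cn(-c4ccc(Cl)cc4)nn3)=CC[C@@]12C` carries 4-chlorophenyl in place of 3-methoxyphenyl on an aromatic nitrogen. The nearest guide is the other swap of the whole group at this place, a 1.6-fold lower number from compound 1 to compound 2 (0.21 log units; within the scatter), together with the two steps above. Among the compounds with values here, none of these steps leaves the scatter in this assay, although no chlorine-bearing compound has been measured yet. The expected result is a 1.1-fold lower number from compound 3 to compound 4 (0.05 log units; within the scatter), so no real change is anticipated. For compound 4 the estimated value is 50000 nM, with an expected range of 22000 nM to 100000 nM.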

Compound 4, half-maximal inhibitory concentration: 35100 nM
Estimate against measurement, compound 4: 1.4-fold (0.15 log units) above; the measured number falls inside the stated range.
By their numbers in this assay, from the lowest: compounds 4, 2, 3 and 1 (each within the scatter of the next).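

Chlorine is the first halogen seen at this place, and 4-chlorophenyl stays within the scatter of all three earlier groups in this assay: (a 1.6-fold lower number from compound 3 to compound 4 (0.20 log units; within the scatter)), (a 1.1-fold lower number from compound 2 to compound 4 (0.06 log units; within the scatter)) and (a 1.9-fold lower number from compound 1 to compound 4 (0.27 log units; within the scatter)). Across these four compounds, then, changing the aryl group on the aromatic nitrogen gives no step beyond the scatter, even with chlorine in the group. Nothing measured here offers an explanation for these small steps. The compounds shown leave open whether an aryl group bearing an amine or a carboxylic acid, or a longer chain in place of the ring, would give a step beyond the scatter.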